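The compounds below may be only part of what the source reports. "The series", "measured", "known", "first", "only" and "open" are said of these compounds alone.

Compound 1 `Cc1nc(N2CCC(N3CCOC3=O)CC2)nc2ccc(NC(=O)/C=C/c3ccc(OC(F)(F)F)cc3)cc12` gives 41 nM in an assay on CHO-K1 cells for displacement of a labelled ligand from melanin-concentrating hormone receptor 1 (Homo sapiens), read by scintillation proximity assay, with a stated time of 2 h; on this read-out lower numbers stand for stronger inhibition and higher numbers for weaker inhibition; compound 2 `Cc1nc(NCCCNS(C)(=O)=O)nc2ccc(NC(=O)/C=C/c3ccc(OC(F)(F)F)cc3)cc12` gives 54 nM, and the step of a 1.3-fold higher number from compound 1 to compound 2 (0.12 log units; within the scatter) does not separate the two. Compound 3 `Cc1nc(N2CCC(N3C(=O)CCC3=O)CC2)nc2ccc(NC(=O)/C=C/c3ccc(OC(F)(F)F)cc3)cc12` differs from compound 1 by 2,5-dioxopyrrolidin-1-yl in place of 2-oxo-1,3-oxazolidin-3-yl on a saturated ring carbon. Within the data shown here, no measured step touches the saturated ring carbon: the one step in hand swaps the whole group on the aromatic carbon and still stays within the scatter of this assay. The exchange of one five-membered ring for another at that carbon is therefore expected to give no step beyond the scatter, a 1.2-fold higher number from compound 1 to compound 3 (0.09 log units; within the scatter). Compound 3 is estimated at 50 nM, within 20 nM to 125 nM.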

Compound 3, half-maximal inhibitory concentration: 94 nM
Beside the measured number, compound 3's estimate is 1.9-fold (0.27 log units) below it, within the range that was stated.
By their numbers in this assay, from the lowest: compounds 1, 2 and 3 (each within the scatter of the next, the first and the last beyond it).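

On the saturated ring carbon, 2,5-dioxopyrrolidin-1-yl in place of 2-oxo-1,3-oxazolidin-3-yl gives a 2.3-fold higher number from compound 1 to compound 3 (0.36 log units; beyond the scatter) in this assay, so this position responds to an exchange of one five-membered ring for another. The step is modest, yet it lies beyond the scatter, although both groups carry no hydrogen-bond donors and the same count of acceptors. Nothing at hand bears on the origin of this step. Still open, as far as these compounds go, is how an amine or a carboxylic acid on this carbon would read, and whether a morpholine ring would fall nearer compound 1 or compound 3.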